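Swapping a methoxy for chloro on a whole-organism read-out

The source may report more compounds than this note shows. Statements on the series, on what has been measured and on what is new or still open speak of the compounds shown alone.

Measured compounds:
compound 1, `COc1cc(OC)c(OC)cc1/C=C/COC(=O)/C=C/c1ccc(F)cc1`, 100%
compound 2, `COc1ccc(/C=C/C(=O)OC/C=C/c2cc(OC)c(OC)cc2OC)cc1`, 100%

Compound 2 was tested in a functional assay on the whole organism (strain Kunming) with Mus musculus as the target, with a stated time of 0.5 h, at a dose of 100 mg/kg by the intraperitoneal route; on this read-out lower numbers stand for a stronger effect and higher numbers for a weaker effect at the one dose given. Among the compounds with values here, there compound 2 gives 100%, and its only measured neighbour, compound 1, gives 100%. Within the data shown here, the one step between them, no change at the digits printed from compound 1 to compound 2 (within the scatter), is a methoxy in place of fluoro on an aromatic carbon, and it left the read-out unchanged within the scatter. Compound 2 thus stands level with compound 1 on the numbers shown.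

Compound 3, `COc1cc(OC)c(OC)cc1/C=C/COC(=O)/C=C/c1ccc(Cl)cc1`, has not yet been measured. It differs from compound 2 by chloro in place of methoxy on an aromatic carbon. Among the measured compounds shown here, the only step that bears on it is the one from compound 1 to compound 2, where a halogen and a methoxy gave the same result within the scatter, as no change at the digits printed from compound 1 to compound 2 (within the scatter) shows. Compound 3 again carries a halogen where compound 2 carries methoxy, so no step beyond the scatter is expected, a number 2 percentage points lower from compound 2 to compound 3 (within the scatter). Compound 3 is therefore estimated at 98%, within 85% to 100%.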

Compound 3, a percentage reported as activity, at one dose (the size of the read-out at that dose, not a potency): 100%
The estimate for compound 3 lay 2 percentage points below the measured number; low and high end bracket the measured number.
By their numbers in this assay, from the lowest: compounds 1, 2 and 3 (each within the scatter of the next).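

In this assay the change from 4-methoxyphenyl to 4-chlorophenyl gives no change at the digits printed from compound 2 to compound 3 (within the scatter) and so adds a second kind of swap on this aromatic carbon, para to a large group, that leaves the read-out where it was. The two halogens can now also be compared directly: chloro in place of fluoro gives no change at the digits printed from compound 1 to compound 3 (within the scatter) and shows that fluoro, chloro and methoxy cannot be told apart at this position on this read-out at the one dose given. No supporting measurement is available to explain why the three compounds give matching results.

As far as these compounds go, since all three compounds give the same number, none of them yet shows a group at this position that moves the read-out, and whether an amine, a carboxylic acid or a longer chain such as butoxy would do so stays open. Also open, from the compounds shown here alone, is whether a change elsewhere on the shared core, such as replacing the ester with an amide, would shift the number in a way these three compounds cannot reveal.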